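The compounds below may be only part of what the source reports. "The series", "measured", "known", "first", "only" and "open" are said of these compounds alone.

Three compounds have so far been measured in a functional assay on MDA-MB-231 cells (Homo sapiens) for cytotoxicity, read by MTT assay, with a stated time of 48 h; on this read-out lower numbers stand for stronger inhibition and higher numbers for weaker inhibition:

compound 1 `O=c1ccoc2cc(OCc3cn(Cc4ccc(Cl)cc4)nn3)ccc12` — > 100000 nM, a limit only
compound 2 `O=c1ccoc2cc(OCc3cn(Cc4ccccc4F)nn3)ccc12` — 29800 nM
compound 3 `O=c1ccoc2cc(OCc3cn(Cc4ccc([N+](=O)[O-])cc4)nn3)ccc12` — 71300 nM

Compound 1 therefore stands at the limit of > 100000 nM in this assay, at which 1 of the 3 values shown sits, so no number is known for it, only that limit. Compound 4 `N#Cc1ccc(Cn2cc(COc3ccc4c(=O)ccoc4c3)nn2)cc1` differs from compound 1 by cyano in place of chloro on an aromatic carbon. The step that bears most directly on this change is an at least 1.4-fold lower number from compound 1 to compound 3 (0.14 log units; that floor lies within the scatter), since nitro also replaces chloro on the same aromatic carbon. The other comparison, an at least 3.3-fold lower number from compound 1 to compound 2 (0.52 log units; beyond the scatter), alters a different position and is only a partial guide. A small lowering, of uncertain size, is thus expected. Compound 4 is estimated at 70000 nM, with a range from 30000 nM to 150000 nM, meaning an expected at least 1.4-fold lower number from compound 1 to compound 4 (0.15 log units; that floor lies within the scatter).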

Compound 4, half-maximal inhibitory concentration: > 100000 nM
Compound 4: only a limit was reported; the forecaster's own chance of this, stated with the estimate: 35%; middle value at least 1.4-fold (0.15 log units) away from the limit.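

With cyano in place of chloro, compound 4 joins compound 1 at a limit in this assay: the limit of > 100000 nM in this assay, at which 2 of the 4 values shown sit.

Both values are limits, so the step between them cannot be read. Two other steps can be read: an at least 3.3-fold higher number from compound 2 to compound 4 (0.52 log units; beyond the scatter), and an at least 1.4-fold higher number from compound 3 to compound 4 (0.14 log units; that floor lies within the scatter). On this aromatic carbon, nitro in compound 3 therefore remains the only group shown that gives a number rather than a limit.

On these data alone, how far compound 1 and compound 4 lie past the limit stays open. So does whether an amine or a carboxylic acid on this same carbon would give a number.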